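This account rests on a few compounds, and the source may have more. Where it says the series, first, only, none or still open, it means among the compounds named here.

Measured in a functional assay on A549 cells (Homo sapiens) for inhibition, read by MTT assay, with a stated time of 72 h; on this read-out lower numbers stand for stronger inhibition and higher numbers for weaker inhibition:

- compound 1 `COc1cc(O)c(CC=C(C)C)c(O)c1C(=O)/C=C/c1ccc(Cl)cc1`: 11800 nM
- compound 2 `COc1cc(O)cc(O)c1C(=O)/C=C/c1ccc(C)cc1`: > 50000 nM

Compound 2 has no number on this read-out. Its > 50000 nM is a limit of the assay, so the starting point of the step is known only from one side.

Compound 3 `COc1cc(O)cc(O)c1C(=O)/C=C/c1ccc(Cl)cc1` is the unmeasured neighbour of compound 2. It has chloro in place of methyl on an aromatic carbon, para to a large group, so that 4-methylphenyl becomes 4-chlorophenyl: chloro in place of methyl on an aromatic carbon.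

Among the compounds with values here, no measured pair isolates this change, so the expectation for this assay is loose. A small step toward stronger inhibition is expected, possibly none beyond the scatter. Within the data shown here, the only guide to the direction is compound 1, which also carries the 4-chlorophenyl and gives 11800 nM. A full move to that level is not expected.

The estimated step is an at least 1.2-fold lower number from compound 2 to compound 3 (0.09 log units; that floor lies within the scatter). For compound 3 the expected value is 40000 nM, with an estimated range from 15000 nM to 90000 nM. A report of only a limit would be no surprise.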

Compound 3, half-maximal inhibitory concentration: 18200 nM
Estimate against measurement, compound 3: 2.2-fold (0.34 log units) above; measured number inside the range.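

In this assay, within the data shown here, chloro in place of methyl on an aromatic carbon, para to a large group, gives an at least 2.7-fold lower number from compound 2 to compound 3 (0.43 log units; beyond the scatter), which is the first reading of any change at this position and shows that 4-chlorophenyl and 4-methylphenyl are not interchangeable here. Hydrogen in place of 3-methylbut-2-en-1-yl on an aromatic carbon gives a 1.5-fold higher number from compound 1 to compound 3 (0.19 log units; within the scatter), so with 4-chlorophenyl in place, compound 1 and compound 3 cannot be told apart on this read-out, and the level of compound 1 is reached without that chain. Compound 2 carries a limit and not a number, so the step to 4-chlorophenyl has a floor but no known size: the limit of > 50000 nM in this assay, at which 1 of the 3 values shown sits.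

Open, going by these compounds, is whether fluoro, bromo, methoxy, an amine or a carboxylic acid on the same aromatic carbon would keep, lower or raise the number seen with chloro. Also open, on these data alone, is whether 3-methylbut-2-en-1-yl would make a difference alongside 4-methylphenyl, and whether a longer chain at its place would separate from hydrogen in this assay.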